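A few compounds are considered here, and "the series" means these few. Any claim that something is new, unique, unknown or untested is made for them only; others in the source may bear on it.

Compound 1 `CN1CCN(C(=O)/C=C/c2ccncc2-c2ccc3ccccc3c2)CC1` stands second highest of the three numbers measured in an assay on a protein complex for inhibition of CDK8/Cyclin C (Homo sapiens), with a stated time of 1 h (on this read-out higher numbers stand for weaker inhibition and lower numbers for stronger inhibition), where compound 1 gives 43.6 nM. Compound 2 `CCOC(=O)/C=C/c1ccncc1-c1ccc2cc[nH]c2c1` gives 12.1 nM in this assay, and compound 3 `CNC(=O)/C=C/c1ccncc1-c1ccc2cnn(C)c2c1` gives 122 nM; both gaps to compound 1 lie beyond the scatter. Compound 4 `O=C(/C=C/c1ccncc1-c1ccc2ccccc2c1)NC1CC1` has not yet been measured in this assay. It differs from compound 1 in a single place: cyclopropylamino in place of 4-methylpiperazin-1-yl on a carbonyl carbon. Going by the values given here, no step between two measured compounds isolates this change, so the expectation rests only on compound 1 and the shared core. For compound 4 the step of a 1.4-fold higher number from compound 1 to compound 4 (0.14 log units; within the scatter) is expected to be small, at most a slight weakening and possibly none beyond the scatter. Compound 4 is therefore estimated at 60 nM, between 20 nM and 180 nM.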

Compound 4, half-maximal inhibitory concentration: 40.1 nM
Beside the measured number, compound 4's estimate is 1.5-fold (0.18 log units) above it, and the stated range covers the measured number.
By their numbers in this assay, from the lowest: compound 2; then compounds 4 and 1 (each within the scatter of the next); then compound 3.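

In this assay, going by these compounds alone, the step of a 1.1-fold lower number from compound 1 to compound 4 (0.04 log units; within the scatter) gives the first direct reading of a change on this carbonyl carbon. On the shared core, cyclopropylamino, with fewer heavy atoms and one hydrogen-bond donor, stands in for 4-methylpiperazin-1-yl with no change beyond the scatter. No measurement here explains why these two groups read alike.

The compounds shown leave open whether morpholin-4-yl, dimethylamino or a longer alkyl chain on the amide nitrogen would read the same on this carbonyl carbon.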